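Replacing a benzamide cap by a free amine

This account rests on a few compounds, and the source may have more. Where it says the series, first, only, none or still open, it means among the compounds named here.

Measured compounds:
- compound 1, `C[C@@H](Nc1c(C(=O)NCc2ccc(F)cc2)nc(Br)c2cccnc12)c1ccccc1`: > 20000 nM in a functional assay on MDA-MB-435 cells (Homo sapiens) for cytotoxicity, read by MTT assay, with a stated time of 72 h; on this read-out lower numbers stand for stronger inhibition and higher numbers for weaker inhibition
- compound 2, `O=C(NCCCNc1c(C(=O)NCc2ccc(F)cc2)nc(Br)c2cccnc12)c1ccccc1`: > 20000 nM
- compound 3, `N[C@H]1CC[C@H](Nc2c(C(=O)Nc3ccccc3)nc(Br)c3cccnc23)CC1`: 1000 nM

Compound 2 gives only a limit in this assay, > 20000 nM. Compound 1 also sits at a limit, > 20000 nM. Going by the values given here, compound 3 is the one compound with a number, 1000 nM, and it is the only one carrying a free amine. Compound 4, `NCCCCCCNc1c(C(=O)NCc2ccc(F)cc2)nc(Br)c2cccnc12`, differs from compound 2 by one change: 3-aminopropyl in place of benzamido on a saturated chain carbon, three bonds along the chain from a nitrogen on an aromatic ring. Among the compounds with values here, no measured pair shows a step of this kind, so the size of the expected step rests on compound 3 alone. Compound 4 is expected to gain somewhat, a step of an at least 2.5-fold lower number from compound 2 to compound 4 (0.39 log units; beyond the scatter), with the estimate 8000 nM, between 1500 nM and 30000 nM.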

Compound 4, half-maximal inhibitory concentration: 6000 nM
Compound 4: middle estimate off by 1.3-fold (0.12 log units), on the high side; measured number inside the range.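

In this assay the swap of benzamido for 3-aminopropyl on this saturated chain carbon turns a limit into a real number, giving an at least 3.3-fold lower number from compound 2 to compound 4 (0.52 log units; beyond the scatter) on the same chain-linked core. Replacing 1-phenylethyl with 6-aminohexyl on the nitrogen on the aromatic ring gives an at least 3.3-fold lower number from compound 1 to compound 4 (0.52 log units; beyond the scatter) as well. Both steps are minimum sizes only, because each starts from a limit rather than a measured number: the limit of > 20000 nM in this assay, at which 2 of the 4 values shown sit. Still open, going by these compounds, is how a hydroxyl or a carboxylic acid in place of the amine, or a shorter or longer chain carrying the amine, would read in this assay.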